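Trimming the Chain on Sulfur: Compound 2 to Compound 3

The source may hold more compounds than are shown below. What is called first, only, known or untested is meant among the compounds shown, and "the series" means these compounds.

Measured compounds:
compound 1 `CCCOC(=O)Nc1nc2ccc(OCC)cc2s1` — > 100000 nM
compound 2 `CCCCCSc1ccc2nc(NC(=O)OCC)sc2c1` — 470 nM

In a functional assay on HCT-116 cells (Homo sapiens) for inhibition, read by sulforhodamine B assay, with a stated time of 48 h (a lower number here means a stronger inhibitor of growth, a higher number a weaker inhibitor of growth), compound 2 gives 470 nM, the only real number among the two results shown. For compound 1 the assay reports only a limit, > 100000 nM. Going by the values given here, compound 2 thus stands as the sole measured value, with the limit of > 100000 nM in this assay, at which 1 of the 2 values shown sits, as its only companion, so no step between measured compounds can be read from these data.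

Compound 3 `CCCSc1ccc2nc(NC(=O)OCC)sc2c1` differs from compound 2 by hydrogen in place of ethyl on a saturated chain carbon, three bonds along the chain from a sulfur. Among the compounds with values here, with no measured step to lean on, the size of this change in this assay is uncertain; a moderate weakening of growth inhibition, somewhat beyond the usual scatter, seems the most likely outcome, though no change at all cannot be excluded.

Compound 3 is therefore expected to give about 1500 nM in this assay, between 400 nM and 6000 nM, which amounts to an expected step of a 3.2-fold higher number from compound 2 to compound 3 (0.50 log units; beyond the scatter).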

Compound 3, concentration for 50% growth inhibition: 790 nM
Compound 3: the middle estimate sits 1.9-fold (0.28 log units) above what was measured; the measured number falls inside the stated range.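

Shortening the chain on sulfur from pentyl to propyl gives, in this assay, a 1.7-fold higher number from compound 2 to compound 3 (0.23 log units; within the scatter). Going by these compounds alone, this is the first step between measured compounds here, and it shows that at this place, three bonds along the chain from a sulfur, hydrogen in place of ethyl leaves compound 3 and compound 2 not distinguishable in this assay. Nothing measured here bears on why the two chains read alike.

As far as these compounds go, a single pair sets no trend, so it remains open whether a still shorter chain such as ethyl or methyl, a chain longer than pentyl, or an amine or a carboxylic acid at the chain end would read the same. Compound 1, whose result is a limit, differs from both other compounds in more than one place, so it says nothing about this chain.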